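Compound 2 gains a cyclobutyl group

The compounds below may be only part of what the source reports. "The series", "measured", "known", "first", "only" and "open" are said of these compounds alone.

Within the data shown here, in an in vitro ADME assay on microsomes from liver (Homo sapiens) for metabolic stability, in the presence of a further agent that is not named here (on this read-out lower numbers stand for slow clearance and higher numbers for fast clearance), compound 2 `COc1ccc(Cl)cc1Cn1c(C(=O)NCC(C)(C)CO)cc2cc(C#N)ccc21` gives 10 mL.min-1.g-1, the lowest of the three numbers so far. Compound 1 `CC(C)(CO)CNC(=O)c1cc2cc(C#N)ccc2n1Cc1cc(Cl)cc(Cl)c1` gives 22 mL.min-1.g-1 and compound 3 `COc1ccc(C)cc1Cn1c(C(=O)NCC(C)(C)CO)cc2cc(C#N)ccc21` gives 23 mL.min-1.g-1, two values within the scatter of each other. Compound 4 `COc1ccc(Cl)cc1Cn1c(C(=O)NCC2(CO)CCC2)cc2cc(C#N)ccc21` has not yet been measured. It differs from compound 2 on a saturated chain carbon bound to an amide-type nitrogen: 1-(hydroxymethyl)cyclobutyl in place of 1-(hydroxymethyl)-1-methylethyl on a saturated chain carbon bound to an amide-type nitrogen.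

Among the measured compounds shown here, no measured step touches that part of the molecule. All of them change the substituted phenyl group instead: a 2.2-fold lower number from compound 1 to compound 2 (0.34 log units; beyond the scatter) and a 2.3-fold higher number from compound 2 to compound 3 (0.36 log units; beyond the scatter) are both modest, while a 1.0-fold higher number from compound 1 to compound 3 (0.02 log units; within the scatter) stays within the scatter. These steps show only how far numbers in this small set have moved, not what the new ring will do. With compound 2 at 10 mL.min-1.g-1, the lowest value seen, a small rise seems the likelier outcome. A step of a 1.4-fold higher number from compound 2 to compound 4 (0.15 log units; within the scatter) is expected. The estimated value for compound 4 is 14 mL.min-1.g-1, with an expected range of 7 mL.min-1.g-1 to 26 mL.min-1.g-1.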

Compound 4, intrinsic clearance in microsomes: 34 mL.min-1.g-1
Compound 4: the middle estimate sits 2.4-fold (0.39 log units) below what was measured; the measured number lies above the stated range.
By their numbers in this assay, from the lowest: compound 2; then compounds 1, 3 and 4 (each within the scatter of the next).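

Among these compounds, until now only the substituted phenyl group had changed, so this is the first reading of the group on a saturated chain carbon bound to an amide-type nitrogen. In this assay the swap of 1-(hydroxymethyl)-1-methylethyl for 1-(hydroxymethyl)cyclobutyl gives a 3.4-fold higher number from compound 2 to compound 4 (0.53 log units; beyond the scatter) and so removes the low clearance number that set compound 2 apart, showing that this part of the molecule also affects the read-out. No measurement shown here explains this rise.

On these data alone, it remains open whether the rise is specific to the four-membered ring or would also appear with a 1-(hydroxymethyl)cyclopentyl group or an open ethyl chain. As far as these compounds go, the effect of replacing the hydroxymethyl with an aminomethyl group, and whether the same ring behaves alike with the phenyl group of compound 1 or compound 3, also remain open.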